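The source may hold more compounds than are shown below. What is called first, only, known or untested is meant among the compounds shown, and "the series" means these compounds.

This account follows the step from compound 3 `CC(C)=CC1C(C(=O)OCC2COCCOCCOCCOCCOCCO2)C1(C)C` to compound 4 `O=C(OCC1COCCOCCOCCOCCOCCO1)c1cccnc1`, two compounds built on the shared core. In a functional assay on SW1573 cells (Homo sapiens) for inhibition, read by sulforhodamine B assay, with a stated time of 48 h (on this read-out higher numbers stand for weaker inhibition of growth and lower numbers for stronger inhibition of growth), compound 3 gives 54000 nM, the highest of the two plain numbers shown. Its nearest neighbour is compound 1 `O=C(/C=C/c1ccccc1)OCC1COCCOCCOCCOCCOCCO1`, which in this assay gives 48000 nM, a gap that lies within the scatter, so no order between the two can be claimed. Compound 2 `O=C(CCCCC1CCCCC1)OCC1COCCOCCOCCOCCO1` in this assay gives only a limit, > 100000 nM, and no number.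

Among the measured compounds shown here, the one measured step, a 1.1-fold higher number from compound 1 to compound 3 (0.05 log units; within the scatter), exchanges the group on the carbonyl carbon and leaves the read-out essentially where it was. Compound 4 differs from compound 3 by pyridin-3-yl in place of 2,2-dimethyl-3-(2-methylprop-1-en-1-yl)cyclopropyl on a carbonyl carbon. For the measured compounds named here, no measured pair tests a pyridin-3-yl group, so the only guide is that changing the group on the carbonyl carbon in a 1.1-fold higher number from compound 1 to compound 3 (0.05 log units; within the scatter) moved the number very little, while compound 2 shows that another change at this position can push the value to the limit (the limit of > 100000 nM in this assay, at which 1 of the 3 values shown sits).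

The writer therefore expects compound 4 to fall in the same range, with a 1.3-fold higher number from compound 3 to compound 4 (0.11 log units; within the scatter) expected to stay within or near the scatter. The estimate for compound 4 is 70000 nM, with a range from 25000 nM to 200000 nM.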

Compound 4, concentration for 50% growth inhibition: > 100000 nM
Compound 4 was reported as a limit (the forecaster's own chance of this, stated with the estimate: 40%); middle value at least 1.4-fold (0.15 log units) away from the limit.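

In this assay compound 4 gives > 100000 nM, which is a limit of the assay and not a number, so any step that ends at compound 4 is known only by its floor. Even so, the step with pyridin-3-yl in place of 2-phenylethenyl, an at least 2.0-fold higher number from compound 1 to compound 4 (0.31 log units; beyond the scatter), is the only step shown at this position that clears the scatter, whereas the floor of the step from the cyclopropyl group, an at least 1.8-fold higher number from compound 3 to compound 4 (0.26 log units; that floor lies within the scatter), does not by itself separate the two compounds. The earlier pair suggested that the group on this carbonyl carbon could be exchanged with little effect, but the new result shows that the position is not indifferent to every exchange, and compound 4 now joins compound 2 at the limit: the limit of > 100000 nM in this assay, at which 2 of the 4 values shown sit.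

A phenyl group at the same place would show whether the ring nitrogen of pyridin-3-yl or the loss of the groups in compound 1 and compound 3 goes with this result. From the compounds shown here alone, how far compound 4 lies past the limit stays open, as does whether an amine or a carboxylic acid on the pyridine ring would bring a measurable value back.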